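This account rests on a few compounds, and the source may have more. Where it says the series, first, only, none or still open, it means among the compounds named here.

Compound 2 `COc1cc(C(=O)N(C)C)ccc1-c1ccc(C(=O)NS(=O)(=O)c2ccc(NCCSc3ccccc3)c([N+](=O)[O-])c2)cc1` stands highest of the two numbers obtained so far: in an assay on isolated protein for binding affinity to Apoptosis regulator Bcl-2 (Homo sapiens), read by fluorescence polarization (a lower number here means a stronger inhibitor, a higher number a weaker inhibitor), compound 2 gives 1980 nM. Within the data shown here, compound 1 `COc1cc(CCC(=O)N(C)C)ccc1-c1ccc(C(=O)NS(=O)(=O)c2ccc(NCCSc3ccccc3)c([N+](=O)[O-])c2)cc1` gives 400 nM in this assay, and the single measured step is a 5.0-fold higher number from compound 1 to compound 2 (0.69 log units; beyond the scatter). Compound 3 `COc1cc(CN(C)C)ccc1-c1ccc(C(=O)NS(=O)(=O)c2ccc(NCCSc3ccccc3)c([N+](=O)[O-])c2)cc1` differs from compound 2 by (dimethylamino)methyl in place of dimethylcarbamoyl on an aromatic carbon. That measured step concerned a different alteration of the same group, so nothing observed bears directly on this change. The step from compound 2 to compound 3 in this assay is therefore expected to stay within the scatter, a 1.5-fold lower number from compound 2 to compound 3 (0.18 log units; within the scatter). Compound 3 is estimated at 1300 nM, ranging from 300 nM to 5000 nM.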

Compound 3, inhibition constant: 4570 nM
The estimate for compound 3 lay 3.5-fold (0.55 log units) below the measured number, within the range that was stated.
By their numbers in this assay, from the lowest: compound 1; then compound 2; then compound 3.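

In this assay, (dimethylamino)methyl on this aromatic carbon gives a 2.3-fold higher number from compound 2 to compound 3 (0.36 log units; beyond the scatter), so a group of similar size without the carbonyl does not bring the number back toward that of compound 1. Measured against the longer 2-(dimethylcarbamoyl)ethyl group, the change is an 11-fold higher number from compound 1 to compound 3 (1.06 log units; beyond the scatter), which leaves compound 3 the weakest of the three. Nothing available accounts for this order.

From the compounds shown here alone, whether a longer chain ending in a dimethylamino group would bring the number closer to that of compound 1 stays open. So does what a carboxylic acid on this aromatic carbon would give.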